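The compounds below may be only part of what the source reports. "The series", "measured", "known", "first", "only" and "open" are said of these compounds alone.

Measured so far in a functional assay on DWD cells (Homo sapiens) for inhibition, read by sulforhodamine B assay; a higher number here means a weaker inhibitor of growth, a lower number a stronger inhibitor of growth:

Compound 1 `c1ccc(-c2ccc(-c3ccc(-c4nc5ccccc5[nH]4)cc3)cc2)cc1`: 100000 nM
Compound 2 `COc1ccc(-c2ccc(-c3ccc(-c4nc5cc(C)ccc5[nH]4)cc3)cc2)cc1OC`: 1720 nM
Compound 3 `FC(F)(F)Oc1ccc(-c2ccc(-c3ccc(-c4nc5ccccc5[nH]4)cc3)cc2)cc1`: 100000 nM

Compound 3 , at 100000 nM, shares the highest of these three numbers with compound 1 . Compound 2 , at 1720 nM, lies far lower, well beyond the scatter. The next compound, compound 4 `CN(C)c1ccc(-c2ccc(-c3ccc(-c4nc5ccccc5[nH]4)cc3)cc2)cc1`, keeps the core of compound 3 and alters one group: dimethylamino in place of trifluoromethoxy on an aromatic carbon, para to a large group (dimethylamino in place of trifluoromethoxy on an aromatic carbon).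

Among the measured compounds shown here, the one measured step that bears on this change is the swap of hydrogen for trifluoromethoxy at the same place, which gave no change at the digits printed from compound 1 to compound 3 (within the scatter). It shows that these two groups read alike, but it says nothing direct about dimethylamino, which has not been measured on this core. Compound 2 differs from compound 1 in more than one place, so its lower number cannot be tied to any single group. It does show that a much lower number is reachable in a close relative. A modest fall in this assay is therefore expected, though no change remains quite possible. The expected step is a 3.3-fold lower number from compound 3 to compound 4 (0.52 log units; beyond the scatter). For compound 4 the estimate is 30000 nM, with an expected range from 3000 nM to 100000 nM.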

Compound 4, concentration for 50% growth inhibition: 100000 nM
The estimate for compound 4 lay 3.3-fold (0.52 log units) below the measured number; the range from low to high includes it.
By their numbers in this assay, from the lowest: compound 2; then compounds 1, 3 and 4 (each within the scatter of the next).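

In this assay, putting dimethylamino in place of trifluoromethoxy gives no change at the digits printed from compound 3 to compound 4 (within the scatter), so swapping one of these groups for the other on this aromatic carbon, para to a large group, does not move the reading. Putting dimethylamino in place of hydrogen gives no change at the digits printed from compound 1 to compound 4 (within the scatter), which extends the earlier result: hydrogen, trifluoromethoxy and dimethylamino now all give the same number at this place on the shared core, although the two larger groups differ in their atoms and size. Nothing available explains why these three compounds read alike.

From the compounds shown here alone, compound 2, at 1720 nM, differs from these compounds in more than one place, so it remains open which of its differences goes with its lower number, and whether any single one would be enough on its own. Also open, going by these compounds, is whether a quite different group at this same place, such as a carboxylic acid, would leave the number where it stands or move it.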